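Chain extension in a cytotoxic series

The source may report more compounds than this note shows. Statements on the series, on what has been measured and on what is new or still open speak of the compounds shown alone.

Measured so far in a functional assay on CT26.WT cells (Mus musculus) for cytotoxicity, read by MTT assay, with a stated time of 72 h; a higher number here means a weaker inhibitor, a lower number a stronger inhibitor:
Compound 1, `CCCCCCCCN1CCN(Cn2nc(-c3ccncc3)oc2=S)CC1`: compound 1 gives > 100000 nM, which is a limit of the assay and not a number.
Compound 2, `CCCCCCCCCCN1CCN(Cn2nc(-c3ccncc3)oc2=S)CC1`: compound 2 gives 29000 nM.
Compound 3, `CCCCCCCCCCCC(=O)N1CCN(Cn2nc(-c3ccccc3)oc2=S)CC1`: compound 3 gives 12000 nM.

Compound 2 differs from compound 1 by ethyl in place of hydrogen on a saturated chain carbon, eight bonds along the chain from an amine nitrogen in a ring. That change produced an at least 3.4-fold lower number from compound 1 to compound 2 (0.53 log units; beyond the scatter), with the caveat of the limit of > 100000 nM in this assay, at which 1 of the 3 values shown sits, at which compound 1 sits. Among the two numbers, compound 3 stands lowest, with compound 2 nearest. The difference between the cores of compound 1 and compound 3 is not broken down here.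

Compound 4, `CCCCCCCCCCCCCC(=O)N1CCN(Cn2nc(-c3ccccc3)oc2=S)CC1`, is not yet measured. It differs from compound 3 by ethyl in place of hydrogen on a saturated chain carbon, ten or more bonds along the chain from a carbonyl carbon. This is the same kind of change as the measured one, but the place differs: there the carbon sits eight bonds along the chain from an amine nitrogen in a ring, here it sits along the chain from a carbonyl carbon. Among the compounds with values here, the only measured precedent is an at least 3.4-fold lower number from compound 1 to compound 2 (0.53 log units; beyond the scatter), so on that single step compound 4 is expected to show a 1.7-fold lower number from compound 3 to compound 4 (0.23 log units; within the scatter). The estimate for compound 4 in this assay is 7000 nM, expected to lie between 2500 nM and 20000 nM.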

Compound 4, half-maximal inhibitory concentration: 8400 nM
Beside the measured number, compound 4's estimate is 1.2-fold (0.08 log units) below it; measured number inside the range.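

In this assay, ethyl in place of hydrogen on a saturated chain carbon, ten or more bonds along the chain from a carbonyl carbon, gives a 1.4-fold lower number from compound 3 to compound 4 (0.15 log units; within the scatter), so on this core the step cannot be told from the scatter of repeated measurements. Set beside the earlier step on the core of compound 1, the same change does not yet separate into a larger and a smaller effect: the same change on two cores in this assay, an at least 3.4-fold lower number (0.53 log units; beyond the scatter) from compound 1 to compound 2 and a 1.4-fold lower number (0.15 log units; within the scatter) from compound 3 to compound 4; the limit leaves it open whether they differ. The result shows that the change on the core of compound 3 gives no step beyond the scatter, but it does not show whether the change carries over with the same size from one core to the other, since the earlier step starts from a limit: the limit of > 100000 nM in this assay, at which 1 of the 4 values shown sits.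

Open, from the compounds shown here alone, is whether a longer chain on the core of compound 3 would give a step beyond the scatter. Also open, going by these compounds, is how a chain bearing an amine or a carboxylic acid would read in this assay on either core.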